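Replacing one aromatic group on compound 3

The source may hold more compounds than are shown below. What is called first, only, known or untested is meant among the compounds shown, and "the series" means these compounds.

Compounds measured in a functional assay on the whole organism (strain Kunming) with Mus musculus as the target, in the formalin test, with a stated time of 0.5 h; a higher number here means that more compound is needed for the effect, a lower number that less compound is needed:
compound 1 `COc1ccccc1/C=C/C(=O)OC/C=C/c1cc(OC)c(OC)cc1OC`: 113 mg/kg
compound 2 `COc1cc(OC)c(OC)cc1/C=C/COC(=O)/C=C/c1ccc(OC)c(OC)c1`: 93.3 mg/kg
compound 3 `COc1cc(OC)c(OC)cc1/C=C/COC(=O)/C=C/c1ccccc1C(F)(F)F`: 123 mg/kg

Compound 3, at 123 mg/kg, stands level with the other two within the scatter, with a 1.1-fold higher number from compound 1 to compound 3 (0.04 log units; within the scatter) and a 1.3-fold higher number from compound 2 to compound 3 (0.12 log units; within the scatter). Compound 4 `COc1cc(OC)c(OC)cc1/C=C/COC(=O)/C=C/c1cccc(Br)c1` differs from it as follows: 3-bromophenyl in place of 2-(trifluoromethyl)phenyl on a double-bonded chain carbon bound to a double-bonded chain carbon. For the measured compounds named here, no measured compound carries 3-bromophenyl, so the data offer no direct precedent. Still, every measured step stayed within the scatter, including a 1.2-fold lower number from compound 1 to compound 2 (0.08 log units; within the scatter), and a 1.3-fold higher number from compound 2 to compound 3 (0.12 log units; within the scatter) changed the group at this same place. No step beyond the scatter is therefore expected, in either direction. The expected change is a 1.2-fold lower number from compound 3 to compound 4 (0.07 log units; within the scatter). For compound 4 the estimated value is 105 mg/kg, with an expected range from 62 mg/kg to 175 mg/kg.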

Compound 4, dose for half-maximal effect: 113 mg/kg
The estimate for compound 4 lay 1.1-fold (0.03 log units) below the measured number; the range from low to high includes it.
By their numbers in this assay, from the lowest: compounds 2, 1, 4 and 3 (each within the scatter of the next).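

In this assay, 3-bromophenyl at this place gave no departure from the other groups: there was a 1.1-fold lower number from compound 3 to compound 4 (0.04 log units; within the scatter), a 1.2-fold higher number from compound 2 to compound 4 (0.08 log units; within the scatter) and no change at the digits printed from compound 1 to compound 4 (within the scatter). A bromine-bearing ring thus joins 2-(trifluoromethyl)phenyl, 3,4-dimethoxyphenyl and 2-methoxyphenyl, and all four groups on a double-bonded chain carbon read alike in this test. Nothing available explains why the number stays flat here.

Going by these compounds, what remains open is whether any group at this place moves the number beyond the scatter. An amine or a carboxylic acid on the ring could show this.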